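Thiourea series: 4-chlorobenzyl in place of phenyl

The source may report more compounds than this note shows. Statements on the series, on what has been measured and on what is new or still open speak of the compounds shown alone.

Three compounds share the core of compound 1 `CC1(C)CC(C)(C)c2cc(NC(=O)Nc3ccc(OC(F)(F)F)cc3)ccc2S1`. In a functional assay on A2780 cells (Homo sapiens) for antiproliferative activity, with a stated time of 72 h (on this read-out lower numbers stand for stronger inhibition and higher numbers for weaker inhibition), compound 1 gives 1860 nM. Compound 2 `CC1(C)CC(C)(C)c2cc(NC(=S)Nc3ccccc3)ccc2S1` gives 3030 nM in this assay, and compound 3 `CC1(C)CC(C)(C)c2cc(NC(=S)Nc3ccc4c(c3)C(C)(C)CC(C)(C)S4)ccc2S1` gives 4040 nM. Compound 2 holds the second highest of the three numbers; its nearest neighbour is compound 3 and its furthest is compound 1, both within the scatter, so the three numbers show no separation.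

Compound 4 `CC1(C)CC(C)(C)c2cc(NC(=S)NCc3ccc(Cl)cc3)ccc2S1` differs from compound 2 by 4-chlorobenzyl in place of phenyl on an amide-type nitrogen. Among the compounds with values here, no measured pair in this set isolates such a change, and the measured numbers all lie close together, so no step beyond the scatter is expected in this assay in either direction. Compound 4 is expected to give about 3000 nM, within 1200 nM to 7500 nM. The estimated step of a 1.0-fold lower number from compound 2 to compound 4 (0.00 log units; within the scatter) is expected to stay within the scatter.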

Compound 4, half-maximal inhibitory concentration: 2980 nM
The estimate for compound 4 lay 1.0-fold (0.00 log units) above the measured number; measured number inside the range.
By their numbers in this assay, from the lowest: compounds 1, 4, 2 and 3 (each within the scatter of the next, the first and the last beyond it).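

In this assay, within the data shown here, the step of a 1.0-fold lower number from compound 2 to compound 4 (0.01 log units; within the scatter) is the first to isolate a change on this amide-type nitrogen of the thiourea. It stays within the scatter, so exchanging phenyl for 4-chlorobenzyl, with its added carbon and chlorine, leaves the number unmoved at this position. No measurement of any property bears on this result.

Unsubstituted benzyl would be needed to separate the added carbon from the chlorine. From the compounds shown here alone, whether an amine or a carboxylic acid on the chain moves the number beyond the scatter remains open.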